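One Added Methyl on a Chain at the Assay Limit

The source may hold more compounds than are shown below. What is called first, only, known or untested is meant among the compounds shown, and "the series" means these compounds.

In a functional assay on Bel-7402 cells (Homo sapiens) for cytotoxicity, read by MTT assay, with a stated time of 72 h (a lower number here means a stronger inhibitor, a higher number a weaker inhibitor), compound 1 (`CCCCC(C)C[C@]1(CC)O[C@H]1[C@]1(CC)C=CC(=O)O1`) gives > 100000 nM as a limit of the assay, not a number. Compound 2 (`CCC[C@@H]1[C@@H](C)C[C@](O)(CC)[C@H]1[C@]1(CC)OC(=O)C[C@@H]1O`) gives > 100000 nM as a limit too. Compound 1 therefore stands with compound 2 at the limit of > 100000 nM in this assay, at which 2 of the 2 values shown sit, and has no exact value. Compound 3 (`CCCCC(CC)C[C@]1(CC)O[C@H]1[C@]1(CC)C=CC(=O)O1`) differs from compound 1 by methyl in place of hydrogen on a saturated chain carbon, three bonds along the chain from a saturated ring carbon on an otherwise unchanged structure, turning 1-methylpentyl into 1-ethylpentyl. Among the measured compounds shown here, no measured pair shows this change, and the expected a number no higher from compound 1 to compound 3 (the limit leaves the size open) in this assay is no shift beyond the scatter, in either direction. Compound 3 is estimated at 100000 nM (range 40000 nM to 200000 nM) and will probably be reported as a limit again.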

Compound 3, half-maximal inhibitory concentration: > 100000 nM
Compound 3 gave a limit, no number (the forecaster's own chance of this, stated with the estimate: 85%); the middle value sits exactly at the limit.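

The step between compound 1 and compound 3 cannot be read, because both compounds give only a limit of the assay: the limit of > 100000 nM in this assay, at which 3 of the 3 values shown sit.

The compounds shown leave open whether any change to this chain or the shared core would give a measurable value.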